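The source may hold more compounds than are shown below. What is called first, only, known or untested is meant among the compounds shown, and "the series" means these compounds.

Measured compounds:
- compound 1 `CCCCCOC(=O)N1CCN(C(=O)[C@H](CCC(=O)O)NC(=O)c2cc(N3CCC(C(=O)N(CC)CC)CC3)nc(-c3ccccc3)n2)CC1` gives 0.21 L/kg
- compound 2 `CCCCCOC(=O)N1CCN(C(=O)[C@H](CCC(=O)O)NC(=O)c2cc(N3CCC(C(=O)NCC)CC3)nc(-c3ccccc3)n2)CC1` gives 0.2 L/kg
- compound 3 `CCCCCOC(=O)N1CCN(C(=O)[C@H](CCC(=O)O)NC(=O)c2nc(-c3ccccc3)cc(N3CCC(COC)CC3)n2)CC1` gives 0.15 L/kg

All three were tested in an in vivo ADME assay on the whole organism (strain Sprague-Dawley) for pharmacokinetics, with Rattus norvegicus as the target; on this read-out lower numbers stand for narrower distribution and higher numbers for wider distribution into tissues. Compound 1 has the highest number of the three, but its distance to compound 2 (a 1.1-fold lower number from compound 1 to compound 2 (0.02 log units; within the scatter)) lies within the scatter, and the values of compound 1 and compound 3 are likewise within the scatter of each other, so none of the three can be set apart from the others.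

The unmeasured compound 4 `CCCCCOC(=O)N1CCN(C(=O)[C@H](CCC(=O)O)NC(=O)c2cc(N3CCC(C(N)=O)CC3)nc(-c3ccccc3)n2)CC1` differs from compound 1 by a single change: amino in place of diethylamino on a carbonyl carbon. Among the compounds with values here, the only step that bears on this is the one from compound 1 to compound 2, where one ethyl on the amide-type nitrogen was replaced by hydrogen and the number barely moved (a 1.1-fold lower number from compound 1 to compound 2 (0.02 log units; within the scatter)). Taking away both ethyls goes one stage further in the same direction, but nothing among the measured compounds suggests a move beyond the scatter in this assay.

Compound 4 is therefore expected to give about 0.18 L/kg, with a range from 0.1 L/kg to 0.32 L/kg, which means an expected step of a 1.2-fold lower number from compound 1 to compound 4 (0.07 log units; within the scatter).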

Compound 4, volume of distribution at steady state: 2.4 L/kg
Compound 4: middle estimate off by 13-fold (1.12 log units), on the low side; measured number outside the range, above it.
By their numbers in this assay, from the lowest: compounds 3, 2 and 1 (each within the scatter of the next); then compound 4.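

In this assay, amino in place of diethylamino on a carbonyl carbon gives an 11-fold higher number from compound 1 to compound 4 (1.06 log units; beyond the scatter) and losing the last ethyl from the amide-type nitrogen gives a 12-fold higher number from compound 2 to compound 4 (1.08 log units; beyond the scatter), whereas losing the first ethyl gave only a 1.1-fold lower number from compound 1 to compound 2 (0.02 log units; within the scatter). This position therefore does not respond in even stages: the large step appears only when the last ethyl goes and a plain carbamoyl remains. Nothing available here accounts for the size of that step.

The compounds shown leave open whether a single methyl on the same nitrogen would behave like the ethyl of compound 2 or like the bare carbamoyl of compound 4. They also leave open what a nitrile would do in place of the carbamoyl on the saturated ring carbon.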